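Methoxycarbonyl in place of ethoxy: a first estimate

A few compounds are considered here, and "the series" means these few. Any claim that something is new, unique, unknown or untested is made for them only; others in the source may bear on it.

Three compounds have values in a functional assay for inhibition, with Homo sapiens as the target; on this read-out lower numbers stand for stronger inhibition and higher numbers for weaker inhibition. Compound 1 `COc1cc(OC)c(C(=O)/C=C/c2ccc(C(=O)O)cc2)c(OC)c1` gives 6230 nM, compound 2 `COc1cccc(C(=O)/C=C/c2ccccc2)c1OC` gives 1670 nM, and compound 3 `CCOc1ccccc1C(=O)/C=C/c1ccccc1` gives 609 nM. Compound 3 has the lowest number of the three, and its gaps to both others lie beyond the scatter.

The next structure is compound 4 `COC(=O)c1ccccc1C(=O)/C=C/c1ccccc1`, with methoxycarbonyl in place of ethoxy on an aromatic carbon, ortho to a large group: methoxycarbonyl in place of ethoxy on an aromatic carbon. For the measured compounds named here, no two measured compounds differ in only one place, so the series offers no direct precedent for this change. The expectation rests only on the spread of values. Compound 3 at 609 nM is the low end of that spread, so weaker inhibition in this assay is the more likely direction, with a size beyond the scatter. The expected move is a 2.5-fold higher number from compound 3 to compound 4 (0.39 log units; beyond the scatter). Compound 4 is estimated at 1500 nM, with an expected range of 500 nM to 5000 nM.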

Compound 4, half-maximal inhibitory concentration: 1950 nM
The estimate for compound 4 lay 1.3-fold (0.11 log units) below the measured number; the range from low to high includes it.
By their numbers in this assay, from the lowest: compound 3; then compounds 2 and 4 (each within the scatter of the next); then compound 1.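

In this assay, for the compounds shown here, the exchange of ethoxy for methoxycarbonyl on an aromatic carbon, ortho to a large group, gives a 3.2-fold higher number from compound 3 to compound 4 (0.51 log units; beyond the scatter) and supplies the first comparison that differs in one place only. This position is therefore not indifferent to the group it carries, and of the two groups compared here ethoxy goes with the lower number and so with the stronger inhibition. This rests on a single pair, and nothing available on these compounds explains the step.

As far as these compounds go, it remains open whether a longer chain such as propoxy would keep the number of compound 3 or move it in either direction. An amine or a carboxylic acid on this same carbon would show how far the position tolerates groups of a different kind.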